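Compound 1 to compound 4: a naphthalene swap on sulfur

A few compounds are considered here, and "the series" means these few. Any claim that something is new, unique, unknown or untested is made for them only; others in the source may bear on it.

Measured so far in a functional assay on HeLa cells (Homo sapiens) for inhibition, read by CCK-8 assay, with a stated time of 72 h, tested at 8 uM; a higher number here means more inhibition of growth at the concentration tested, a lower number less inhibition of growth
- compound 1 `Cc1cc(C)cc(SCc2ccc(/C=C/C(=O)Nc3ccccc3N)cc2)c1` gives 3.39%
- compound 2 `Nc1ccccc1NC(=O)c1ccc(CSc2cccc(F)c2)cc1` gives 78.4%
- compound 3 `Nc1ccccc1NC(=O)c1ccc(CSc2ccc(Br)cc2)cc1` gives 38.2%

Compound 1 stands lowest of the three, and the values of compound 2 and compound 3 both lie well clear of it. The next compound to be tested is compound 4 `Nc1ccccc1NC(=O)/C=C/c1ccc(CSc2cccc3ccccc23)cc1`, which keeps the core of compound 1 and changes only the aryl group: naphthalen-1-yl in place of 3,5-dimethylphenyl on a sulfur. In words, this is naphthalen-1-yl in place of 3,5-dimethylphenyl on a sulfur.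

For the measured compounds named here, only one measured step bears on this change, a number 40.2 percentage points lower from compound 2 to compound 3 (beyond the scatter). It is large and also swaps the aryl group on the sulfur, so the group at this place can matter in this assay. Going by the values given here, that step, however, belongs to the core shared by compound 2 and compound 3, not to the core of compound 1, and no measured compound carries naphthalen-1-yl. Its direction therefore does not carry over. Compound 1 at 3.39% leaves little room downward, so a modest rise is the more likely outcome, possibly no larger than the scatter, with a small chance of a much larger one. The expected change is a number 8.6 percentage points higher from compound 1 to compound 4 (within the scatter). For compound 4 the estimated value is 12%, with an expected range from 0% to 40%.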

Compound 4, percent growth inhibition at one concentration: 22.1%
Compound 4: middle estimate off by 10.1 percentage points, on the low side; low and high end bracket the measured number.
By their numbers in this assay, from the lowest: compound 1; then compound 4; then compound 3; then compound 2.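

In this assay, the group on a sulfur whose other neighbours are a saturated chain carbon now has a measured effect on the core of compound 1, with a number 18.7 percentage points higher from compound 1 to compound 4 (beyond the scatter). For the compounds shown here, the only earlier step at this place, a number 40.2 percentage points lower from compound 2 to compound 3 (beyond the scatter), belongs to a different core, so this is the first evidence that changing the group there can also shift growth inhibition on the core of compound 1, here with naphthalen-1-yl, a group that none of the earlier compounds carries. The entering group has 2 six-membered aromatic rings of carbon only where the leaving group has one, but no measurement shown gives a reason for the rise.

Going by these compounds, whether naphthalen-1-yl would have a similar effect on the core shared by compound 2 and compound 3 remains open, as the two steps share neither a core nor a group. Also open, on these data alone, is how the core of compound 1 would respond to naphthalen-2-yl, a benzyl group or a longer alkyl chain on the sulfur, which would test whether the rise is specific to naphthalen-1-yl.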